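Notes on a myeloperoxidase inhibitor series, compounds 1 to 3

The source may report more compounds than this note shows. Statements on the series, on what has been measured and on what is new or still open speak of the compounds shown alone.

Measured so far:
compound 1, `Nc1cc(Cc2ccn(Cc3ccc4c(c3)CCNC4)n2)c2nn[nH]c2n1`: 58 nM
compound 2, `Nc1cc(Cc2ccn(Cc3cccc(Oc4cccc5c4CNC5)c3)n2)c2nn[nH]c2n1`: 26 nM

In an assay on isolated protein for inhibition of Myeloperoxidase (Homo sapiens), with a stated time of 10 min (on this read-out lower numbers stand for stronger inhibition and higher numbers for weaker inhibition), compound 1 gives 58 nM and compound 2 gives 26 nM. Compound 2 stands at the lowest number of the two, and the gap to compound 1 lies beyond the usual scatter of this assay. Compound 3 `Nc1cc(Cc2ccn(Cc3cccc(C4CCNCC4)c3)n2)c2nn[nH]c2n1` has not been measured yet. It differs from compound 2 in one place: a group of 6 heavy atoms (5 carbon, 1 nitrogen; one six-membered non-aromatic ring with 1 hetero atom) in place of a group of 10 heavy atoms (8 carbon, 1 nitrogen, 1 oxygen; one five-membered non-aromatic ring with 1 hetero atom, one six-membered aromatic ring of carbon only), on an aromatic carbon. For the measured compounds named here, no step between measured compounds isolates a change of this kind, so the expectation rests only on the two known values and on the change itself. Since a smaller group replaces a larger one while the single hydrogen-bond donor is retained, a modest loss in this assay is expected, with a step of a 2.7-fold higher number from compound 2 to compound 3 (0.43 log units; beyond the scatter) that may just exceed the scatter. For compound 3 the expected value is 70 nM, with a range from 20 nM to 250 nM.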

Compound 3, half-maximal inhibitory concentration: 100 nM
Estimate against measurement, compound 3: 1.4-fold (0.15 log units) below; measured number inside the range.
By their numbers in this assay, from the lowest: compound 2; then compounds 1 and 3 (each within the scatter of the next).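

For the compounds shown here, replacing the group of 10 heavy atoms with piperidin-4-yl on this aromatic carbon gives a 3.8-fold higher number from compound 2 to compound 3 (0.59 log units; beyond the scatter) in this assay and is the first single change that can be read. This position is therefore not indifferent to the group it carries, although the step is modest and compound 3 still gives 100 nM with the smaller group in place. Nothing available explains the size of this step.

The change swaps the whole group at once, so these compounds cannot show which part of the group of 10 heavy atoms accounts for the difference. From the compounds shown here alone, how an aminomethyl group or a carboxylic acid would read on the same aromatic carbon also remains open.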